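This account rests on a few compounds, and the source may have more. Where it says the series, first, only, none or still open, it means among the compounds named here.

In a functional assay on A549 cells (Homo sapiens) for antiproliferative activity, read by MTT assay, with a stated time of 48 h (on this read-out lower numbers stand for stronger inhibition and higher numbers for weaker inhibition), compound 1 `Cc1c(C(=O)NCC(O)CO)oc2ccc(N(Cc3ccc(Br)cc3)S(=O)(=O)c3ccc(Br)cc3)cc12` gives 30500 nM and compound 2 `Cc1c(C(=O)N2CCCC(C)C2)oc2ccc(N(Cc3ccc(Br)cc3)S(=O)(=O)c3ccc(Br)cc3)cc12` gives 33700 nM so these two stand level within the scatter, and compound 2 has no other measured neighbour. Compound 3 `Cc1ccc(NC(=O)c2oc3ccc(N(Cc4ccc(Br)cc4)S(=O)(=O)c4ccc(Br)cc4)cc3c2C)nc1` carries (5-methylpyridin-2-yl)amino in place of 3-methylpiperidin-1-yl on a carbonyl carbon, and (5-methylpyridin-2-yl)amino in place of 3-methylpiperidin-1-yl on a carbonyl carbon gives the count of that difference. For the measured compounds named here, one measured step bears on this place: the change of a 1.1-fold higher number from compound 1 to compound 2 (0.04 log units; within the scatter) lies within the scatter, with 3-methylpiperidin-1-yl replacing (2,3-dihydroxypropyl)amino on the same carbonyl carbon. This is thin evidence, as no aromatic ring at this place has been measured yet. In this assay no step beyond the scatter is therefore expected. The estimated step is a 1.1-fold lower number from compound 2 to compound 3 (0.05 log units; within the scatter) as a central figure. For compound 3 the expected value is 30000 nM with an estimated range from 10000 nM to 80000 nM on this read-out.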

Compound 3, half-maximal inhibitory concentration: > 40000 nM
Compound 3: only a limit was reported (the forecaster's own chance of this, stated with the estimate: 20%); at least 1.3-fold (0.12 log units) between middle value and limit.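

In this assay compound 3 reads as a limit and not as a number: the limit of > 40000 nM in this assay, at which 1 of the 3 values shown sits. The steps read an at least 1.1-fold higher number from compound 2 to compound 3 (0.07 log units; that floor lies within the scatter) and an at least 1.3-fold higher number from compound 1 to compound 3 (0.11 log units; that floor lies within the scatter), so neither step can be sized beyond these floors. New at this place is that an aromatic ring with an amide hydrogen on the carbonyl carbon gives no lower number than 2,3-dihydroxypropyl or 3-methylpiperidin-1-yl, and none of the three groups has yet shown a step beyond the scatter.

From the compounds shown here alone, how far compound 3 lies past its limit stays open, and with it whether the pyridine ring weakens inhibition at all. Also open, going by these compounds, is whether piperazin-1-yl or a free carboxylic acid in place of these amides would move the number beyond the scatter.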